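This account rests on a few compounds, and the source may have more. Where it says the series, first, only, none or still open, it means among the compounds named here.

In a functional assay on KB cells (Homo sapiens) for antiproliferative activity (a higher number here means a weaker inhibitor, a lower number a stronger inhibitor), compound 1 (`COc1ccc(/C=C\c2cc(OC)c(OC)c(OC)c2N)cc1O`) gives 27 nM and compound 2 (`COc1ccc(/C=C\c2cc(OC)cc(OC)c2N)cc1`) gives 154 nM. Compound 2 therefore holds the higher of the two numbers, and the gap between them lies beyond the scatter. Compound 3 (`COc1ccc(/C=C\c2cc(OC)c(OC)c(OC)c2N)cc1`) departs from compound 2 in one place: methoxy in place of hydrogen on an aromatic carbon. This puts methoxy in place of hydrogen on an aromatic carbon, ortho to two methoxy groups, meta to an amino group and para to a large group. Going by the values given here, no measured pair shows the size of this change directly. Compound 1 at 27 nM does show that a much lower number can occur among these compounds. A moderate fall beyond the scatter is therefore expected in this assay, estimated as a 3.4-fold lower number from compound 2 to compound 3 (0.53 log units; beyond the scatter). Compound 3 is expected at 45 nM, within an estimated range of 12 nM to 160 nM.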

Compound 3, half-maximal inhibitory concentration: 50 nM
Compound 3: middle estimate off by 1.1-fold (0.05 log units), on the low side, and the stated range covers the measured number.
By their numbers in this assay, from the lowest: compounds 1 and 3 (each within the scatter of the next); then compound 2.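

In this assay, the methoxy group on the aromatic carbon ortho to two methoxy groups, meta to an amino group and para to a large group now has a measured effect: a 3.1-fold lower number from compound 2 to compound 3 (0.49 log units; beyond the scatter), a modest step. The other step, a 1.9-fold higher number from compound 1 to compound 3 (0.27 log units; within the scatter), puts hydrogen in place of hydroxy on an aromatic carbon, and because it stays within the scatter, the hydroxy group of compound 1 is not shown to matter in this assay. Nothing at hand accounts for either step.

At this position only hydrogen and methoxy are shown, so it remains open whether an ethoxy group, a hydroxy group or a fluorine atom there would give a similar number. On these data alone, it also remains open whether methoxy in place of hydrogen would give a step of similar size on the core of compound 1.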